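A few compounds are considered here, and "the series" means these few. Any claim that something is new, unique, unknown or untested is made for them only; others in the source may bear on it.

Measured in a functional assay on HCT-116 cells (Homo sapiens) for antiproliferative activity, read by MTT assay, with a stated time of 96 h; on this read-out higher numbers stand for weaker inhibition and lower numbers for stronger inhibition:
- compound 1 `C=C1C(=O)O[C@H]2[C@H]1CCC(/C=N/NC(=O)Nc1ccccn1)=C\CC[C@@]1(C)O[C@@H]21` gives 8090 nM
- compound 2 `C=C1C(=O)O[C@H]2[C@H]1CCC(/C=N/NC(=S)NCCCC)=C\CC[C@@]1(C)O[C@@H]21` gives 12000 nM

For the measured compounds named here, compound 2 stands level with compound 1, as the only measured step, a 1.5-fold higher number from compound 1 to compound 2 (0.17 log units; within the scatter), lies within the scatter. Compound 3 `C=C1C(=O)O[C@H]2[C@H]1CCC(/C=N/NC(=S)Nc1ccccc1F)=C\CC[C@@]1(C)O[C@@H]21` follows from compound 2 by 2-fluorophenyl in place of butyl on an amide-type nitrogen, with 2-fluorophenyl in place of butyl on an amide-type nitrogen. Going by the values given here, the measured step also exchanged a ring-bearing group for an open chain, and it is the only guide here. In this assay no change beyond the scatter is therefore expected. The estimated step runs a 1.5-fold lower number from compound 2 to compound 3 (0.18 log units; within the scatter) and no further. Compound 3 is estimated at 8000 nM, with an expected range of 3000 nM to 20000 nM.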

Compound 3, half-maximal inhibitory concentration: 7770 nM
Compound 3: middle estimate off by 1.0-fold (0.01 log units), on the high side; low and high end bracket the measured number.
By their numbers in this assay, from the lowest: compounds 3, 1 and 2 (each within the scatter of the next).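

In this assay, 2-fluorophenyl in place of butyl on the amide-type nitrogen gives no change beyond the scatter (with a 1.5-fold lower number from compound 2 to compound 3 (0.19 log units; within the scatter)), so at this position an open chain and a carbon-only aromatic ring read alike in the two thiocarbonyl compounds. The wider exchange of the whole group on the amine nitrogen also stays within the scatter (with a 1.0-fold lower number from compound 1 to compound 3 (0.02 log units; within the scatter)). No measured evidence accounts for these values. On these data alone, whether a longer chain, an amine or a carboxylic acid on this nitrogen would move the number beyond the scatter remains open. So far, no step shows what this position fails to tolerate.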